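The source may report more compounds than this note shows. Statements on the series, on what has been measured and on what is new or still open speak of the compounds shown alone.

Working notes on the series.

Compound 3 `Nc1nc(-c2ccco2)nc2sc(CN3CC=CCC3)cc12` gives the lowest number among the three compounds measured in an assay on CHO-K1 cells for antagonist activity at adenosine receptor A1 (Homo sapiens), read by a beta-galactosidase reporter, with stated times of 15 min and 6 h (on this read-out lower numbers stand for stronger inhibition and higher numbers for weaker inhibition), namely 150 nM. Compound 1 `CN(C)Cc1cc2c(N)nc(-c3ccco3)nc2s1` gives 3550 nM in this assay, and compound 2 `Nc1nc(-c2ccco2)nc2sc(CNC3CCCCC3)cc12` gives 2480 nM; the step of a 1.4-fold lower number from compound 1 to compound 2 (0.16 log units; within the scatter) is small, while a 24-fold lower number from compound 1 to compound 3 (1.37 log units; beyond the scatter) and a 17-fold lower number from compound 2 to compound 3 (1.22 log units; beyond the scatter) are large. Compound 4 `Nc1nc(-c2ccco2)nc2sc(CN3CCC(F)CC3)cc12` differs from compound 3 by a group of 7 heavy atoms (5 carbon, 1 nitrogen, 1 fluorine; one six-membered non-aromatic ring with 1 hetero atom) in place of a group of 6 heavy atoms (5 carbon, 1 nitrogen; one six-membered non-aromatic ring with 1 hetero atom), on a saturated chain carbon bound to an aromatic carbon. Among the measured compounds shown here, the ring carrying the double bond outside aromatic rings is what set compound 3 apart from compounds 1 and 2; no measured pair shows the effect of removing that double bond or of adding fluorine. Compound 4 is therefore expected to give a higher number in this assay, with the step of a 3.0-fold higher number from compound 3 to compound 4 (0.48 log units; beyond the scatter) estimated but uncertain. The estimate for compound 4 is 450 nM, in a range from 120 nM to 1800 nM.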

Compound 4, inhibition constant: 740 nM
Compound 4: middle estimate off by 1.6-fold (0.22 log units), on the low side, within the range that was stated.
By their numbers in this assay, from the lowest: compound 3; then compound 4; then compounds 2 and 1 (each within the scatter of the next).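

In this assay, the 4-fluoropiperidin-1-yl group on this saturated chain carbon stands apart from both earlier amines, with a 4.8-fold lower number from compound 1 to compound 4 (0.68 log units; beyond the scatter) and a 3.4-fold lower number from compound 2 to compound 4 (0.53 log units; beyond the scatter). It still does not match the ring of compound 3, with a 4.9-fold higher number from compound 3 to compound 4 (0.69 log units; beyond the scatter), so among these compounds, a six-membered non-aromatic ring with 1 hetero atom does not alone set the number. Nothing available explains this change.

The compounds shown leave open how an unsubstituted piperidin-1-yl group would read here. That group would separate the loss of the double bond from the entry of the fluorine.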